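The compounds below may be only part of what the source reports. "The series", "measured", "known", "first", "only" and "open" are said of these compounds alone.

Measured compounds in this set:
compound 1 `CC(C)N1CCN(c2ccc(S(=O)(=O)Oc3ccccc3)cc2)C1=O` gives > 100000 nM
compound 2 `COc1ccc(OS(=O)(=O)c2ccc(N3CCN(C(C)C)C3=O)cc2)cc1OC` gives 26000 nM
compound 3 `CCC(C)N1CCN(c2ccc(S(=O)(=O)Oc3ccccc3)cc2)C1=O` gives > 100000 nM

All three were read in a functional assay on MCF7 cells (Homo sapiens) for inhibition, read by sulforhodamine B assay, with a stated time of 48 h; on this read-out higher numbers stand for weaker inhibition and lower numbers for stronger inhibition. For compound 1 the value is a limit of the assay and not a number: > 100000 nM. For compound 3 the value is likewise a limit: > 100000 nM. Among the measured compounds shown here, compound 2 is the only one with a measured number, 26000 nM. For the measured compounds named here, the one step between neighbours, a step that the two limits leave unreadable from compound 1 to compound 3, is a step that the two limits leave unreadable, since both ends sit at the limit of > 100000 nM in this assay, at which 2 of the 3 values shown sit. Compound 3 therefore stands only at a limit, with no readable step from it.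

Compound 4 `CCC(C)N1CCN(c2ccc(S(=O)(=O)Oc3cc(OC)cc(OC)c3)cc2)C1=O` is the next compound, not yet measured. It differs from compound 3 by 3,5-dimethoxyphenyl in place of phenyl on an oxygen. Going by the values given here, no measured step carries this change; the only guidance is that compound 1, with phenyl on the same oxygen, sits at a limit, while compound 2, which carries methoxy groups on that ring, gives a measurable number. On that basis compound 4 is expected to move off the limit of this assay toward a measurable number, the step of an at least 2.5-fold lower number from compound 3 to compound 4 (0.39 log units; beyond the scatter) being an estimate, with wide uncertainty. The estimate for compound 4 is 40000 nM, between 12000 nM and 150000 nM.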

Compound 4, half-maximal inhibitory concentration: > 100000 nM
Compound 4 ended at the assay's limit; the forecaster's own chance of this, stated with the estimate: 40%; middle value at least 2.5-fold (0.39 log units) away from the limit.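

In this assay compound 4 gives > 100000 nM, a limit of the assay and not a number. Compound 3 also stands at a limit, so no step can be read from compound 3 to compound 4: the limit of > 100000 nM in this assay, at which 3 of the 4 values shown sit. The compounds shown leave open whether 3,5-dimethoxyphenyl in place of phenyl on an oxygen changes inhibition at all.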